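This account rests on a few compounds, and the source may have more. Where it says the series, first, only, none or still open, it means among the compounds named here.

Of the compounds shown here, three sharing one core have been tested in an ADME assay on HCT-116 cells (Homo sapiens) for cytotoxicity, read by CellTiter-Glo, with a stated time of 72 h (a lower number here means a stronger inhibitor, a higher number a weaker inhibitor), and none of them has yielded a number. Compound 1, `CC1CCN(C2CCN(S(=O)(=O)c3cn(C)cn3)CC2)CC1`, gives only a limit, > 10000 nM. Compound 2, `CC1CCN(C2CCN(S(=O)(=O)c3ccc(F)cc3F)CC2)CC1`, likewise reaches only a limit, > 5000 nM. Compound 3, `Cc1cccc(S(=O)(=O)N2CCC(N3CCC(C)CC3)CC2)c1`, the starting point here, also stops at a limit, > 5000 nM. The three steps among them, a step that the two limits leave unreadable from compound 1 to compound 2, a step that the two limits leave unreadable from compound 1 to compound 3 and a step that the two limits leave unreadable from compound 2 to compound 3, thus have no readable size: the limit of > 10000 nM in this assay, at which 1 of the 3 values shown sits, and the limit of > 5000 nM in this assay, at which 2 of the 3 values shown sit, together cover every value shown. Compound 3 therefore stands where both of its neighbours stand, at the weak edge of what this assay can report. Compound 4, `CC1CCN(C2CCN(S(=O)(=O)c3cncc(Br)c3)CC2)CC1`, differs from it in one place: 5-bromopyridin-3-yl in place of 3-methylphenyl on a sulfonyl sulfur. For the measured compounds named here, none of the measured steps bears readably on this change; each runs between two limits. Compound 4 is therefore expected in this assay to give 10000 nM, with a range of 3000 nM to 30000 nM, most likely again as a limit. The expected step is a step that the limit leaves unreadable from compound 3 to compound 4, that is, nothing beyond the scatter.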

Compound 4, half-maximal inhibitory concentration: > 10000 nM
Compound 4: a limit, no number; the forecaster's own chance of this, stated with the estimate: 80%; the middle value lies on the limit itself.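

In this assay compound 4 gives > 10000 nM as a limit and not a number. Its steps from compound 1, compound 2 and compound 3 cannot be read, since each runs between two limits. The compounds shown leave open whether any group on the sulfonyl sulfur yields a measurable number in this assay at all.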